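A second trifluoromethyl group on compound 2

A few compounds are considered here, and "the series" means these few. Any claim that something is new, unique, unknown or untested is made for them only; others in the source may bear on it.

Measured so far in a functional assay on KG-1 cells (Homo sapiens) for cytotoxicity, read by luminescence and CellTiter-Glo, with a stated time of 3 days (a lower number here means a stronger inhibitor, a higher number a weaker inhibitor), are three compounds:
compound 1 `O=C(Nc1cc(C(F)(F)F)cc(C(F)(F)F)c1)c1ccc(Br)cc1O` gives 830 nM
compound 2 `O=C(Nc1cccc(C(F)(F)F)c1)c1cc(F)ccc1O` gives 1010 nM
compound 3 `O=C(Nc1ccc(Cl)c(C(F)(F)F)c1)c1cc(F)ccc1O` gives 540 nM

Compound 2 stands at 1010 nM and lies within the scatter of both other compounds. Compound 4 `O=C(Nc1cc(C(F)(F)F)cc(C(F)(F)F)c1)c1cc(F)ccc1O` has not yet been measured. Compared with compound 2, it carries trifluoromethyl in place of hydrogen on an aromatic carbon. Within the data shown here, the only measured step of a similar kind is chloro in place of hydrogen on an aromatic carbon, which gives a 1.9-fold lower number from compound 2 to compound 3 (0.27 log units; within the scatter) and is a different group on the same kind of atom. Compound 1 has the same trifluoromethyl groups as compound 4 but differs elsewhere, and compound 1 gives 830 nM in this assay within the scatter of compound 2. Neither observation points to a large shift, so the expected result in this assay is a 1.6-fold lower number from compound 2 to compound 4 (0.19 log units; within the scatter) and nothing beyond the scatter. Compound 4 is estimated at 650 nM with an expected range from 280 nM to 1400 nM in this assay.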

Compound 4, half-maximal inhibitory concentration: 470 nM
The estimate for compound 4 lay 1.4-fold (0.14 log units) above the measured number; the range from low to high includes it.
By their numbers in this assay, from the lowest: compounds 4, 3, 1 and 2 (each within the scatter of the next, the first and the last beyond it).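

In this assay, among these compounds, trifluoromethyl in place of hydrogen on an aromatic carbon, meta to a trifluoromethyl group, gives a 2.1-fold lower number from compound 2 to compound 4 (0.33 log units; beyond the scatter), a modest change, but the first single step here to pass beyond the scatter. With both trifluoromethyl groups held fixed, 5-fluoro-2-hydroxyphenyl in place of 4-bromo-2-hydroxyphenyl on a carbonyl carbon gives a 1.8-fold lower number from compound 1 to compound 4 (0.25 log units; within the scatter), so that exchange cannot be told apart from repeat variation. Nothing available here bears on the origin of the trifluoromethyl step.

From the compounds shown here alone, whether a methoxy group, an amine or a carboxylic acid on the same aromatic carbon would move the number further remains open. Also open, going by these compounds, is whether the trifluoromethyl step would hold with 4-bromo-2-hydroxyphenyl in place of 5-fluoro-2-hydroxyphenyl.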